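The source may hold more compounds than are shown below. What is called first, only, known or untested is meant among the compounds shown, and "the series" means these compounds.

Measured compounds in a functional assay on MCF7 cells (Homo sapiens) for antiproliferative activity; a lower number here means a stronger inhibitor, a higher number a weaker inhibitor:
- compound 1 `COc1cc(Cc2nc3c(N)ncnc3n2CC2CCCO2)cc(OC)c1OC`: 91200 nM
- compound 2 `COc1cc(Cc2nc3c(N)ncnc3n2CC2CCC2)cc(OC)c1OC`: 45700 nM
- compound 3 `C=CCCn1c(Cc2cc(OC)c(OC)c(OC)c2)nc2c(N)ncnc21`: 40700 nM

All three share one core and differ only in the group on the saturated chain carbon bound to the aromatic nitrogen. Of the three numbers, that of compound 3 is the lowest, but the step of a 1.1-fold lower number from compound 2 to compound 3 (0.05 log units; within the scatter) is within the scatter, so compound 2 and compound 3 cannot be told apart; only a 2.2-fold lower number from compound 1 to compound 3 (0.35 log units; beyond the scatter) separates compound 3 from compound 1, and that step is modest.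

Compound 4 `C/C=C/Cn1c(Cc2cc(OC)c(OC)c(OC)c2)nc2c(N)ncnc21` carries the same atoms as compound 3, joined differently: prop-1-en-1-yl in place of allyl on a saturated chain carbon bound to an aromatic nitrogen. The change sits at the same place that the three measured steps probe, and each of those steps stayed small: a 2.0-fold lower number from compound 1 to compound 2 (0.30 log units; within the scatter), a 2.2-fold lower number from compound 1 to compound 3 (0.35 log units; beyond the scatter), a 1.1-fold lower number from compound 2 to compound 3 (0.05 log units; within the scatter). Swapping a ring for an open chain, or a ring for a chain with a double bond, moved the numbers little, so moving the double bond one position within a chain of the same size is expected to give no step beyond the scatter in this assay; the expected step is a 1.0-fold higher number from compound 3 to compound 4 (0.01 log units; within the scatter).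

Compound 4 is therefore estimated at 42000 nM, with a range from 18000 nM to 95000 nM.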

Compound 4, half-maximal inhibitory concentration: 51300 nM
Compound 4: middle estimate off by 1.2-fold (0.09 log units), on the low side; the measured number falls inside the stated range.
By their numbers in this assay, from the lowest: compounds 3, 2, 4 and 1 (each within the scatter of the next, the first and the last beyond it).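

In this assay, moving the double bond one position along the chain, read as but-3-en-1-yl to but-2-en-1-yl on a saturated chain carbon bound to an aromatic nitrogen, gives a step that does not register (a 1.3-fold higher number from compound 3 to compound 4 (0.10 log units; within the scatter)), so the two isomers cannot be told apart. Compound 4 also cannot be separated from the ring-bearing compounds (a 1.1-fold higher number from compound 2 to compound 4 (0.05 log units; within the scatter); a 1.8-fold lower number from compound 1 to compound 4 (0.25 log units; within the scatter)), which leaves the step from compound 1 to compound 3 as the only one among these four compounds beyond the scatter. Nothing available explains why the numbers at this position stay so close.

The compounds shown leave open whether a group of a different kind at this place, such as a primary amine, a carboxylic acid or a longer chain such as hexyl, would give a step beyond the scatter. They also leave open whether the cis form of the but-2-en-1-yl group would behave like compound 4.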